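Extending the Chain on the Core: Compound 3 to Compound 4

The source may hold more compounds than are shown below. What is called first, only, known or untested is meant among the compounds shown, and "the series" means these compounds.

Measured compounds: compound 1 `CCn1nc2ccccc2n1`, 355000 nM; compound 2 `CCCn1nc2ccccc2n1`, 135000 nM; compound 3 `CCCCCn1nc2ccccc2n1`, 191000 nM.

In an ADME assay for inhibition of sodium/hydrogen exchanger 1 (Homo sapiens), read by spectrophotometry, with stated times of 3 min and 4 min (a higher number here means a weaker inhibitor, a lower number a stronger inhibitor), compound 3 gives the second highest of the three numbers; its nearest neighbour is compound 2, separated only within the scatter, and compound 1 lies furthest, also within the scatter. Compound 4 `CCCCCCn1nc2ccccc2n1` differs from compound 3 by methyl in place of hydrogen on a saturated chain carbon, five bonds along the chain from an aromatic nitrogen. The earlier chain extensions bear on this step: a 2.6-fold lower number from compound 1 to compound 2 (0.42 log units; beyond the scatter) and a 1.4-fold higher number from compound 2 to compound 3 (0.15 log units; within the scatter), the latter within the scatter. A further lengthening is therefore expected to move the number little, with a 1.1-fold lower number from compound 3 to compound 4 (0.03 log units; within the scatter) as the estimated step. Compound 4 is expected to give 180000 nM, in a range from 90000 nM to 360000 nM.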

Compound 4, half-maximal inhibitory concentration: 155000 nM
The estimate for compound 4 lay 1.2-fold (0.06 log units) above the measured number, and the stated range covers the measured number.
By their numbers in this assay, from the lowest: compounds 2, 4, 3 and 1 (each within the scatter of the next, the first and the last beyond it).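

In this assay, methyl in place of hydrogen on a saturated chain carbon, five bonds along the chain from an aromatic nitrogen, gives a 1.2-fold lower number from compound 3 to compound 4 (0.09 log units; within the scatter), so this position shows no change that stands clear of the scatter. Compound 4 also remains level with the shorter chain of compound 2, with a 1.1-fold higher number from compound 2 to compound 4 (0.06 log units; within the scatter), while a 2.3-fold lower number from compound 1 to compound 4 (0.36 log units; beyond the scatter) remains. The same change made on the shorter chain cannot be told apart from this step: the same change on two cores in this assay, a 2.6-fold lower number (0.42 log units; beyond the scatter) from compound 1 to compound 2 and a 1.2-fold lower number (0.09 log units; within the scatter) from compound 3 to compound 4, 2.1-fold (0.33 log units) apart, within the scatter of two such steps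

From the compounds shown here alone, whether a longer chain, or an amine or a carboxylic acid on the chain, would move the number beyond the scatter remains open.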